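From a 3-fluorophenyl to a 2-hydroxyphenyl group on the carbonyl

The source may report more compounds than this note shows. Statements on the series, on what has been measured and on what is new or still open speak of the compounds shown alone.

Values so far in a functional assay (Homo sapiens) for inhibition (on this read-out lower numbers stand for stronger inhibition and higher numbers for weaker inhibition), for two compounds

Compound 1 `CCCCOc1ccccc1C(=O)/C=C/c1cc(OC)cc(OC)c1` gives 13000 nM
Compound 2 `COc1cc(/C=C/C(=O)c2cccc(F)c2)cc(OC)c1` gives 9200 nM

On these numbers compound 2 stands alongside compound 1, since the two values lie within the usual scatter of each other and the pair cannot be ranked. Compound 3 `COc1cc(/C=C/C(=O)c2ccccc2O)cc(OC)c1` has not yet been measured. It carries 2-hydroxyphenyl in place of 3-fluorophenyl on a carbonyl carbon and otherwise matches compound 2.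

Within the data shown here, no pair of measured compounds differing in one place shows what such a change does, so the data offer no direct guide to its size. With compound 2 at 9200 nM as the only anchor, no shift beyond the scatter is expected in this assay in either direction. The estimated change is a 1.2-fold lower number from compound 2 to compound 3 (0.06 log units; within the scatter) and this is a small expected step with real uncertainty around it. Compound 3 is expected at 8000 nM (estimated range 2500 nM to 25000 nM) in this assay with the width of that range reflecting how little the two measured values can support.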

Compound 3, half-maximal inhibitory concentration: 8100 nM
Compound 3: middle estimate off by 1.0-fold (0.01 log units), on the low side; low and high end bracket the measured number.
By their numbers in this assay, from the lowest: compounds 3, 2 and 1 (each within the scatter of the next).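

In this assay, 2-hydroxyphenyl in place of 3-fluorophenyl on a carbonyl carbon gives a 1.1-fold lower number from compound 2 to compound 3 (0.06 log units; within the scatter), which lies within the scatter, so a ring with a hydrogen-bond donor and acceptor and a ring with neither cannot be told apart at this position. Hydrogen in place of butyl on an oxygen on an aromatic ring gives a 1.6-fold lower number from compound 1 to compound 3 (0.21 log units; within the scatter), also within the scatter, so this first reading at that oxygen does not separate the butyl ether from the free hydroxyl. Nothing further is available to explain why these compounds read alike.

The compounds shown leave open whether any group on this carbonyl carbon can move the number beyond the scatter, and the step from compound 2 to compound 3 cannot separate the identity of the ring substituent from where it sits, since both differ. Also open, from the compounds shown here alone, is how an amine or a carboxylic acid on this ring would read, or how a methyl group or a chain longer than butyl would read on the oxygen.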